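From nitro to chloro: estimating growth inhibition

The compounds below may be only part of what the source reports. "The series", "measured", "known", "first", "only" and "open" are said of these compounds alone.

Compound 1 `CC1=CC[C@@H]([C@@](C)(O)CCCC(C)(C)NC(=S)N/N=C\c2ccccc2)CC1`: 20900 nM
Compound 2 `CC1=CC[C@@H]([C@@](C)(O)CCCC(C)(C)NC(=S)N/N=C\c2ccccc2[N+](=O)[O-])CC1`: 7840 nM
Compound 3 `CC1=CC[C@@H]([C@@](C)(O)CCCC(C)(C)NC(=S)N/N=C\c2ccc([N+](=O)[O-])cc2)CC1`: 9560 nM
Compound 4 `CC1=CC[C@@H]([C@@](C)(O)CCCC(C)(C)NC(=S)N/N=C\c2ccc(Cl)cc2)CC1`: not yet measured

In a functional assay on K562 cells (Homo sapiens) for cytotoxicity, read by sulforhodamine B assay (on this read-out lower numbers stand for stronger inhibition of growth and higher numbers for weaker inhibition of growth), compound 3 gives 9560 nM. It cannot be told apart from its nitro-bearing partner, since the move of that group gives a 1.2-fold higher number from compound 2 to compound 3 (0.09 log units; within the scatter). Both nitro compounds lie under the parent without nitro, with a 2.7-fold lower number from compound 1 to compound 2 (0.43 log units; beyond the scatter) and a 2.2-fold lower number from compound 1 to compound 3 (0.34 log units; beyond the scatter).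

Compound 4 chloro in place of nitro on an aromatic carbon has chloro in place of nitro on an aromatic carbon, para to a large group. Within the data shown here, no chloro compound has been measured, so the guidance is indirect. The nearest evidence is the step that introduced the nitro group now being replaced, a 2.2-fold lower number from compound 1 to compound 3 (0.34 log units; beyond the scatter), and it is only modest. A large change is therefore not expected, and no clear direction can be claimed, though a slight drift toward compound 1 seems plausible. The estimated outcome is a 1.2-fold higher number from compound 3 to compound 4 (0.06 log units; within the scatter), which would stay within the scatter. For compound 4 the estimated value is 11000 nM, with an expected range from 5500 nM to 22000 nM.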

Compound 4, concentration for total growth inhibition: 730 nM
Estimate against measurement, compound 4: 15-fold (1.18 log units) above; measured number below the stated range.
By their numbers in this assay, from the lowest: compound 4; then compounds 2 and 3 (each within the scatter of the next); then compound 1.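

Swapping nitro for chloro at this place on the ring gives a 13-fold lower number from compound 3 to compound 4 (1.12 log units; beyond the scatter) in this assay, so the choice of group here can matter far more than the two nitro compounds suggested. Against the unsubstituted parent, chloro gives a 29-fold lower number from compound 1 to compound 4 (1.46 log units; beyond the scatter) and so goes well past the modest step that nitro gave with a 2.2-fold lower number from compound 1 to compound 3 (0.34 log units; beyond the scatter) on the same ring. The step to 4-chlorophenyl from 2-nitrophenyl, an 11-fold lower number from compound 2 to compound 4 (1.03 log units; beyond the scatter) here, is of similar size, so what counts in these compounds is which group is added and not only that one is present.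

From the compounds shown here alone, with a single chloro compound, it stays open whether a bromo, methyl or methoxy group in the same place would behave like chloro or like nitro. Nothing measured here explains why chloro and nitro differ so strongly.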